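A few compounds are considered here, and "the series" means these few. Any claim that something is new, unique, unknown or untested is made for them only; others in the source may bear on it.

Measured compounds in a functional assay on the whole organism for inhibition, with Mythimna separata as the target, with a stated time of 5 days; on this read-out higher numbers stand for an effect only at larger amounts of compound and lower numbers for an effect already at smaller amounts:
- compound 1 `CC(C)(C)n1ncc(OCc2nnc(-c3ccc(Br)cc3)o2)c(Cl)c1=O`: 21400 nM
- compound 2 `CC(C)(C)n1ncc(OCc2nnc(-c3ccc(Cl)cc3Cl)s2)c(Cl)c1=O`: 62200 nM
- compound 3 `Cc1nnc(COc2cnn(C(C)(C)C)c(=O)c2Cl)o1`: a limit of the assay, > 299000 nM

Compound 3 stands at the weak end of the numbers shown. In this assay compound 3 gives no number, only the limit > 299000 nM, the one case of the limit of > 299000 nM in this assay, at which 1 of the 3 values shown sits.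

Compound 4 `CC(C)(C)n1ncc(OCc2nnc(-c3cccc(F)c3)o2)c(Cl)c1=O` differs from compound 3 by 3-fluorophenyl in place of methyl on an aromatic carbon. For the measured compounds named here, the one measured step that bears on this change is the reverse one, an at least 13-fold higher number from compound 1 to compound 3 (1.14 log units; beyond the scatter), a large step in which an aryl group was replaced by methyl and the number rose to the limit. Compound 4 reinstates an aryl group at that carbon, so a large step back toward the number of compound 1 is expected, in the direction of a lower number. Compound 2, which also carries an aryl group there on a different five-membered ring, gives 62200 nM, again a number rather than a limit.

Compound 4 is therefore expected at about 30000 nM, with a range from 10000 nM to 150000 nM. This estimate means an expected step of an at least 9.9-fold lower number from compound 3 to compound 4 (0.99 log units; beyond the scatter).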

Compound 4, half-maximal effective concentration: 7100 nM
The estimate for compound 4 lay 4.2-fold (0.63 log units) above the measured number; measured number outside the range, below it.
By their numbers in this assay, from the lowest: compound 4; then compound 1; then compound 2. At a limit, above all of these: compound 3.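

In this assay, 3-fluorophenyl in place of methyl gives an at least 42-fold lower number from compound 3 to compound 4 (1.62 log units; beyond the scatter), so the rise seen on going to methyl is undone by a second aryl group and is not tied to 4-bromophenyl alone. Compound 3 sits at a limit, so this step gives only a minimum size: the limit of > 299000 nM in this assay, at which 1 of the 4 values shown sits. The choice of aryl group also counts at this aromatic carbon: 3-fluorophenyl in place of 4-bromophenyl gives a 3.0-fold lower number from compound 1 to compound 4 (0.48 log units; beyond the scatter), a modest step but one beyond the scatter.

Compound 1 and compound 4 differ in both the halogen and where it sits on the phenyl ring, so the two effects cannot be separated here. As far as these compounds go, how an unsubstituted phenyl, a pyridyl ring, a benzyl group or a longer alkyl chain would read at this carbon stays open.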